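Notes on the sulfonyl aryl group of the series

A few compounds are considered here, and "the series" means these few. Any claim that something is new, unique, unknown or untested is made for them only; others in the source may bear on it.

Going by the values given here, in an assay on MDA-MB-231 cells for binding affinity to C-X-C chemokine receptor type 4 (Homo sapiens), read by fluorescence and microscopy, with stated times of 10 min and 30 min (a lower number here means that less compound is needed, a higher number that more compound is needed for the effect), compound 3 `O=C(NCc1ccc(CNS(=O)(=O)c2ccccc2F)cc1)c1ccc(F)cc1` gives 10 nM, the lowest of the three numbers measured so far. Compound 1 `O=C(NCc1ccc(CNS(=O)(=O)c2ccc([N+](=O)[O-])cc2)cc1)c1ccc(F)cc1` gives 1000 nM in this assay, and compound 2 `O=C(NCc1ccc(CNS(=O)(=O)c2cccnc2)cc1)c1ccc(F)cc1` gives 1000 nM; these two lie within the scatter of each other, with no change at the digits printed from compound 1 to compound 2 (within the scatter). The steps of a 100-fold lower number from compound 1 to compound 3 (2.00 log units; beyond the scatter) and a 100-fold lower number from compound 2 to compound 3 (2.00 log units; beyond the scatter) both show that the group on the sulfonyl sulfur sets the number to a large degree.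

Compound 4 `O=C(NCc1ccc(CNS(=O)(=O)c2cccc(F)c2)cc1)c1ccc(F)cc1` differs from compound 3 by 3-fluorophenyl in place of 2-fluorophenyl on a sulfonyl sulfur. Among the compounds with values here, no measured step moves the fluorine within the ring; the two steps into compound 3 exchange the whole group, so their size tells only that this part of the shared core is sensitive, not in which direction a shift of the fluorine will act. With that sensitivity in mind, a number between compound 3 and compounds 1 and 2 is expected, with wide uncertainty. Compound 4 is estimated at 100 nM, within a range of 10 nM to 1000 nM. This estimate amounts to an expected 10-fold higher number from compound 3 to compound 4 (1.00 log units; beyond the scatter) in this assay.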

Compound 4, effective concentration (reported as EC, without a stated level of effect): 1000 nM
Beside the measured number, compound 4's estimate is 10-fold (1.00 log units) below it; measured number inside the range.
By their numbers in this assay, from the lowest: compound 3; then compounds 1, 2 and 4 (each within the scatter of the next).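

In this assay, moving the fluorine alone gives a 100-fold higher number from compound 3 to compound 4 (2.00 log units; beyond the scatter) with no atom gained or lost, so this position responds to where the fluorine sits on the ring, which the earlier exchanges of the whole group could not show. The 3-fluorophenyl group also falls with the other two groups, with no change at the digits printed from compound 2 to compound 4 (within the scatter) and no change at the digits printed from compound 1 to compound 4 (within the scatter) on record, so among the four compounds only the 2-fluorophenyl group of compound 3 stands apart. Nothing at hand explains the gap between the two fluorophenyl groups.

Open, on these data alone, is whether this low number belongs to fluorine itself or would also appear with a 2-chlorophenyl or 2-methylphenyl group on the sulfonyl sulfur. Also open, as far as these compounds go, is where a 4-fluorophenyl group would fall.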